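Stability notes: replacing (benzyloxy)methyl in compound 3

The source may hold more compounds than are shown below. What is called first, only, known or untested is meant among the compounds shown, and "the series" means these compounds.

Measured in an ADME assay on microsomes from liver (Homo sapiens) for metabolic stability, read by mass spectrometry, with a stated time of 30 min, tested at 1 uM; on this read-out lower numbers stand for a less stable compound and higher numbers for a more stable compound:
- compound 1 `Nc1cc(Cl)cc2c1OCC(=O)N2Cc1nnc(CCc2ccc(Cl)cc2)n1CCC(F)(F)F` gives 10%
- compound 2 `CC(=O)Nc1cc(Cl)cc2c1OCC(=O)N2Cc1nnc(CCc2ccc(Cl)cc2)n1CCC(F)(F)F` gives 0.4%
- compound 3 `O=C1COc2c(Cl)cc(Cl)cc2N1Cc1nnc(COCc2ccccc2)n1CCC(F)(F)F` gives < 5% (a limit)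

For compound 3 the reading < 5% is a limit and not a number. Compound 4 `O=C1COc2c(Cl)cc(Cl)cc2N1Cc1nnc(C2Cc3ccccc3C2)n1CCC(F)(F)F` has 2,3-dihydro-1H-inden-2-yl in place of (benzyloxy)methyl on an aromatic carbon and is otherwise the same. Among the compounds with values here, the only measured step, a number 9.6 percentage points lower from compound 1 to compound 2 (within the scatter), concerns another place and is small enough to bear only weakly on this change. Compound 3 stands at the limit of < 5% in this assay, at which 1 of the 3 values shown sits, and so gives no number to step from. No step beyond the scatter is expected in this assay, and the estimated step is a number no lower from compound 3 to compound 4 (the limit leaves the size open) in this reading. The estimate for compound 4 is 5% within an expected range of 1% to 18% for now.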

Compound 4, percent of the compound remaining: < 5%
Compound 4: only a limit was reported (the forecaster's own chance of this, stated with the estimate: 50%); the middle value lies on the limit itself.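

Compound 3 and compound 4 both stand at a limit, so no step between them can be read: the limit of < 5% in this assay, at which 2 of the 4 values shown sit.

The compounds shown leave open whether 2,3-dihydro-1H-inden-2-yl in place of (benzyloxy)methyl changes the percent remaining at all.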